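Swapping the Aryl Group on a Piperidine Nitrogen

The source may hold more compounds than are shown below. What is called first, only, known or untested is meant among the compounds shown, and "the series" means these compounds.

Compound 1, `O=C(Nc1ccc2cc[nH]c2c1)C1CCN(c2cccc(C(F)(F)F)c2)CC1`: > 9000 nM
Compound 2, `O=C1COc2ccc(NC(=O)C3CCN(c4cccc(Br)c4)CC3)cc2N1`: 330 nM
Compound 3, `CC(=O)N1CCc2ccc(NC(=O)C3CCN(c4cccc(C(F)(F)F)c4)CC3)cc21`: 800 nM

All three were tested in a functional assay for antagonist activity at transient receptor potential cation channel subfamily V member 1 (Homo sapiens), read by FLIPR and calcium flux; a lower number here means a stronger inhibitor, a higher number a weaker inhibitor. For compound 1 the result is only a limit of the assay, > 9000 nM. Among the two real numbers, compound 2 stands lowest; compound 3 sits higher, and that gap is beyond the usual scatter. Compound 4, `Cc1c(Cl)cccc1N1CCC(C(=O)Nc2ccc3c(c2)NC(=O)CO3)CC1`, is not yet measured. It differs from compound 2 in one place: 3-chloro-2-methylphenyl in place of 3-bromophenyl on an amine nitrogen in a ring. For the measured compounds named here, no step of this kind has been measured in this set, so its direction is open; the expectation is a change no larger than the scatter, a 1.3-fold lower number from compound 2 to compound 4 (0.12 log units; within the scatter). Compound 4 is therefore expected to give about 250 nM, within a range from 80 nM to 800 nM.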

Compound 4, half-maximal inhibitory concentration: 100 nM
Estimate against measurement, compound 4: 2.5-fold (0.40 log units) above; measured number inside the range.
By their numbers in this assay, from the lowest: compound 4; then compound 2; then compound 3. At a limit, above all of these: compound 1.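

In this assay, for the compounds shown here, this is the first measured step in the set, and replacing 3-bromophenyl with 3-chloro-2-methylphenyl gives a 3.3-fold lower number from compound 2 to compound 4 (0.52 log units; beyond the scatter). The aryl group on this amine nitrogen in a ring therefore affects the result, and an aryl group carrying both chlorine and a methyl group is tolerated here. Nothing measured here explains this step. Bromine gives way to chlorine as the methyl group enters, so the share of each change stays unknown. From the compounds shown here alone, how an amine or a carboxylic acid on this aryl ring would behave also remains open.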